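This account rests on a few compounds, and the source may have more. Where it says the series, first, only, none or still open, it means among the compounds named here.

Compound 1 `Cc1cc(O)c(C2=NN(c3ccc(S(N)(=O)=O)cc3)C(c3ccccc3O)C2)cc1Cl` and compound 2 `Cc1cc(O)c(C2=NN(c3ccc(S(N)(=O)=O)cc3)C(/C=C/c3ccccc3)C2)cc1Cl` share one core. In a functional assay on U-251 cells (Homo sapiens) for antiproliferative activity, with a stated time of 48 h (a higher number here means a weaker inhibitor of growth, a lower number a stronger inhibitor of growth), compound 1 gives 2780 nM and compound 2 gives 3790 nM; the change a 1.4-fold higher number from compound 1 to compound 2 (0.13 log units; within the scatter) put 2-phenylethenyl in place of 2-hydroxyphenyl on a saturated ring carbon. Compound 2 thus holds the highest of the two numbers, yet its gap to compound 1 lies within the scatter. Compound 3 `COc1ccc(C2CC(c3cc(Cl)c(C)cc3O)=NN2c2ccc(S(N)(=O)=O)cc2)cc1OC` differs from compound 2 by 3,4-dimethoxyphenyl in place of 2-phenylethenyl on a saturated ring carbon. Among the compounds with values here, only that one step bears on this change, and it stayed within the scatter, so no shift beyond the scatter is expected: a 1.3-fold lower number from compound 2 to compound 3 (0.10 log units; within the scatter). Compound 3 is therefore estimated at 3000 nM, with a range from 1300 nM to 7000 nM.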

Compound 3, concentration for 50% growth inhibition: 3710 nM
For compound 3 the middle estimate is 1.2-fold (0.09 log units) below the measured one; measured number inside the range.
By their numbers in this assay, from the lowest: compounds 1, 3 and 2 (each within the scatter of the next).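

In this assay, this saturated ring carbon has now carried three different groups with no shift beyond the scatter: a 1.0-fold lower number from compound 2 to compound 3 (0.01 log units; within the scatter), and a 1.3-fold higher number from compound 1 to compound 3 (0.13 log units; within the scatter). Adding the two methoxy groups of 3,4-dimethoxyphenyl therefore leaves the number within the scatter of those given by 2-hydroxyphenyl and 2-phenylethenyl. Nothing available accounts for this lack of change. Still open, going by these compounds, is whether a phenyl ring carrying an amine or a carboxylic acid at this carbon would move the number beyond the scatter. On these data alone, whether the same flat picture holds in other cell lines also remains open.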